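Side-chain change from compound 3 to compound 4

The source may hold more compounds than are shown below. What is called first, only, known or untested is meant among the compounds shown, and "the series" means these compounds.

In a functional assay on L1210 cells (Mus musculus) for inhibition (on this read-out lower numbers stand for stronger inhibition and higher numbers for weaker inhibition), compound 3 `CCCC(=O)OCCNc1ncnc2c1C(=O)C(OC)=CC2=O` gives 2660 nM. Compound 2 `COC(=O)CNc1ncnc2c1C(=O)C(OC)=CC2=O` gives 4260 nM, within the scatter of compound 3. Compound 1 `COC(=O)C(CC(C)C)NC(=O)C(CC(C)C)Nc1ncnc2c1C(=O)C(OC)=CC2=O` gives 1300 nM, a lower number that lies beyond the scatter of compound 3.

The next structure is compound 4 `CCN(CC)CCCNc1ncnc2c1C(=O)C(OC)=CC2=O`, and the change to it is (diethylamino)methyl in place of (propylcarbonyl)oxy on a saturated chain carbon, two bonds along the chain from a nitrogen on an aromatic ring. In words, (diethylamino)methyl stands in place of (propylcarbonyl)oxy on a saturated chain carbon, two bonds along the chain from a nitrogen on an aromatic ring.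

Among the compounds with values here, one measured step bears on this chain: a 1.6-fold lower number from compound 2 to compound 3 (0.20 log units; within the scatter). There, ((propylcarbonyl)oxy)methyl takes the place of methoxycarbonyl, and the change stays within the scatter. Within the data shown here, no measured compound carries the entering group, so this step offers only limited guidance and the range has to stay wide.

No shift beyond the scatter is expected, and the estimated step is a 1.3-fold lower number from compound 3 to compound 4 (0.12 log units; within the scatter). For compound 4 the expected value is 2000 nM, with an estimated range of 650 nM to 6000 nM.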

Compound 4, half-maximal inhibitory concentration: 1240 nM
Beside the measured number, compound 4's estimate is 1.6-fold (0.21 log units) above it; measured number inside the range.
By their numbers in this assay, from the lowest: compounds 4 and 1 (each within the scatter of the next); then compounds 3 and 2 (each within the scatter of the next).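

On the saturated chain carbon, two bonds along the chain from a nitrogen on an aromatic ring, (diethylamino)methyl in place of (propylcarbonyl)oxy gives a 2.1-fold lower number from compound 3 to compound 4 (0.33 log units; beyond the scatter) in this assay and so moves the number beyond the scatter, which a 1.6-fold lower number from compound 2 to compound 3 (0.20 log units; within the scatter) did not do. Starting from the methoxycarbonyl chain, 2-(diethylamino)ethyl gives a 3.4-fold lower number from compound 2 to compound 4 (0.54 log units; beyond the scatter) in this assay and points the same way, so this side chain does respond to the group it carries, though both steps are modest. No supporting evidence is available to explain these shifts.

The compounds shown leave open whether the shift belongs to the diethylamino group or to the chain that carries it. A dimethylamino group, a primary amine or a longer chain ending in the same amine would separate these readings.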